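A Hydroxy Group Gives Way to Dimethylamino

The compounds below may be only part of what the source reports. "The series", "measured", "known", "first", "only" and "open" are said of these compounds alone.

Compound 1 `NS(=O)(=O)c1ccc(/C=C/c2ccc(F)cc2)cc1`: 16300 nM
Compound 2 `NS(=O)(=O)c1ccc(/C=C/c2ccc(O)cc2)cc1`: 11100 nM
Compound 3 `CN(C)c1ccc(/C=C/c2ccc(S(N)(=O)=O)cc2)cc1`: not yet measured

Going by the values given here, in a functional assay on KM12 cells (Homo sapiens) for inhibition (on this read-out lower numbers stand for stronger inhibition of growth and higher numbers for weaker inhibition of growth), compound 2 gives 11100 nM, and compound 1, the only other measured compound, gives 16300 nM. These two numbers lie within the scatter of each other. Compound 3 carries dimethylamino in place of hydroxy on an aromatic carbon, para to a large group: dimethylamino in place of hydroxy on an aromatic carbon. Among the compounds with values here, the one measured step that bears on this change is a 1.5-fold lower number from compound 1 to compound 2 (0.17 log units; within the scatter). It came with hydroxy in place of fluoro on an aromatic carbon, and it is small. Within the data shown here, no measured compound carries dimethylamino, so this single step is thin evidence and the range must stay wide. No change beyond the scatter is expected, and the estimated step is a 1.1-fold lower number from compound 2 to compound 3 (0.05 log units; within the scatter). For compound 3 the estimated value is 10000 nM, with an expected range from 3000 nM to 30000 nM.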

Compound 3, concentration for 50% growth inhibition: 8280 nM
Compound 3: middle estimate off by 1.2-fold (0.08 log units), on the high side; the measured number falls inside the stated range.
By their numbers in this assay, from the lowest: compounds 3, 2 and 1 (each within the scatter of the next).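

In this assay, the aromatic carbon para to a large group now holds a third kind of group, and dimethylamino, with more heavy atoms and no hydrogen-bond donor, replaces hydroxy with a 1.3-fold lower number from compound 2 to compound 3 (0.13 log units; within the scatter). Dimethylamino in place of fluoro gives a 2.0-fold lower number from compound 1 to compound 3 (0.29 log units; within the scatter), so across these compounds neither the larger group nor the loss of the donor moves the number beyond the scatter. Nothing available explains why the number stays this flat.

Still open, on these data alone, is whether any group at this position can shift growth inhibition beyond the scatter, since fluoro, hydroxy and dimethylamino all leave it there. A carboxylic acid or a longer chain such as butoxy on the same carbon would test this, with the rest of the core unchanged.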